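A few compounds are considered here, and "the series" means these few. Any claim that something is new, unique, unknown or untested is made for them only; others in the source may bear on it.

In a functional assay on HT-29 cells (Homo sapiens) for cytotoxicity, read by MTT assay, with a stated time of 72 h (a higher number here means a weaker inhibitor, a lower number a stronger inhibitor), compound 2 `COc1cccc(-c2cc(C(=O)Nc3ccc(Oc4ccnc5cc(OCCCN6CCCCC6)c(OC)cc45)c(F)c3)c3cc(F)ccc3n2)c1` gives 2500 nM, the higher of the two numbers recorded, and stands beyond the scatter from compound 1 `COc1cc2c(Oc3ccc(NC(=O)c4cc(-c5ccccc5)nc5ccc(F)cc45)cc3F)ccnc2cc1OCCCN1CCCCC1`, which gives 120 nM. Compound 3 `COc1cc2c(Oc3ccc(NC(=O)c4cc(-c5ccc(C)cc5)nc5ccc(F)cc45)cc3F)ccnc2cc1OCCCN1CCCCC1` differs from compound 2 by 4-methylphenyl in place of 3-methoxyphenyl on an aromatic carbon. For the measured compounds named here, the one measured step that bears on this change is a 21-fold higher number from compound 1 to compound 2 (1.32 log units; beyond the scatter), so taking the methoxy away is expected to lower the number, while the entering methyl is not covered by any step and leaves the size uncertain. Compound 3 is therefore expected to show a 13-fold lower number from compound 2 to compound 3 (1.10 log units; beyond the scatter) in this assay. The value of compound 3 is estimated at 200 nM, with a range from 60 nM to 800 nM.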

Compound 3, half-maximal inhibitory concentration: 500 nM
Estimate against measurement, compound 3: 2.5-fold (0.40 log units) below; the measured number falls inside the stated range.
By their numbers in this assay, from the lowest: compound 1; then compound 3; then compound 2.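

In this assay, 4-methylphenyl in place of 3-methoxyphenyl gives a 5.0-fold lower number from compound 2 to compound 3 (0.70 log units; beyond the scatter), so the penalty seen at this position is not common to every substituted phenyl. The methyl still does not match plain phenyl, giving a 4.2-fold higher number from compound 1 to compound 3 (0.62 log units; beyond the scatter), and compound 1 keeps the lowest number of the three. Nothing measured here explains these differences. Because the group and its place on the phenyl change together between compound 2 and compound 3, their contributions cannot be separated. On these data alone, how an amine or a carboxylic acid on this phenyl would behave also remains open.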